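Working notes: chloro in place of dimethylamino

The compounds below may be only part of what the source reports. "The series", "measured", "known", "first", "only" and "open" are said of these compounds alone.

Measured in a functional assay on K562 cells (Homo sapiens) for cytotoxicity, read by sulforhodamine B assay; on this read-out lower numbers stand for stronger inhibition of growth and higher numbers for weaker inhibition of growth:
- compound 1 `CC1=CC[C@@H]([C@@](C)(O)CCCC(C)(C)NC=S)CC1`: > 100000 nM (a limit)
- compound 2 `COc1ccc(/C=N\NC(=S)NC(C)(C)CCC[C@](C)(O)[C@@H]2CC=C(C)CC2)cc1`: 34900 nM
- compound 3 `CC1=CC[C@@H]([C@@](C)(O)CCCC(C)(C)NC(=S)N/N=C\c2ccc(N(C)C)cc2)CC1`: 42000 nM

Not yet measured: compound 4 `CC1=CC[C@@H]([C@@](C)(O)CCCC(C)(C)NC(=S)N/N=C\c2ccc(Cl)cc2)CC1`.

Going by the values given here, compound 3 stands level with compound 2, and these are the only two compounds with numbers so far. Among the compounds with values here, compound 1 stands at a limit of this assay, recorded as the limit of > 100000 nM in this assay, at which 1 of the 3 values shown sits, and so gives no size of step.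

The next change is chloro in place of dimethylamino on an aromatic carbon, para to a large group. Within the data shown here, one measured step bears on it. Dimethylamino in place of methoxy at that aromatic carbon gave a 1.2-fold higher number from compound 2 to compound 3 (0.08 log units; within the scatter). This is a single step and chloro has not yet been tested, so the range stays wide. No shift beyond the scatter is expected in this assay, and no direction is favoured with any confidence. The expected size of the change is a 1.2-fold lower number from compound 3 to compound 4 (0.07 log units; within the scatter). For compound 4 the estimated value is 36000 nM, with an expected range of 15000 nM to 85000 nM.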

Compound 4, concentration for total growth inhibition: 730 nM
The estimate for compound 4 lay 49-fold (1.69 log units) above the measured number; the whole stated range lies above it.
By their numbers in this assay, from the lowest: compound 4; then compounds 2 and 3 (each within the scatter of the next). At a limit, above all of these: compound 1.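

In this assay, the group on this aromatic carbon, para to a large group, proves decisive: chloro gives a 58-fold lower number from compound 3 to compound 4 (1.76 log units; beyond the scatter) in place of dimethylamino, and a 48-fold lower number from compound 2 to compound 4 (1.68 log units; beyond the scatter) in place of methoxy. Methoxy and dimethylamino had stood within the scatter of each other, so that pair alone showed no sensitivity at this position, whereas the two chloro steps show a large one. Nothing measured here gives a cause for these steps.

Fluoro, bromo, nitrile or plain hydrogen at this carbon would show whether the step is particular to chloro or shared with other groups. Also open, going by these compounds, is whether the same change would carry the same size of step on a different core.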